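This account rests on a few compounds, and the source may have more. Where it says the series, first, only, none or still open, it means among the compounds named here.

Measured compounds:
Compound 1, `Fc1cccc(-c2nc(Nc3ccccc3)c3ccccc3n2)c1`, in a functional assay on MCF7 cells (Homo sapiens) for cytotoxicity, read by MTT assay, with a stated time of 48 h (on this read-out lower numbers stand for stronger inhibition and higher numbers for weaker inhibition), gives > 50000 nM.
Compound 2, `Fc1ccc2nc(-c3ccccc3)nc(Nc3ccccc3)c2c1`, in this assay gives > 50000 nM.
Compound 3, `Fc1cccc(-c2nc(Nc3cccc(Cl)c3)c3cc(F)ccc3n2)c1`, in this assay gives > 50000 nM.

Each of these three values is a limit of the assay and not a measured number: the compound did not reach half-maximal inhibition at the highest concentration tested. Compound 3 therefore stands exactly where the other two stand, at the limit, and no ranking among the three is possible. The picture is summed up by the limit of > 50000 nM in this assay, at which 3 of the 3 values shown sit.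

Compound 4, `Oc1cccc(Nc2nc(-c3cccc(F)c3)nc3ccc(F)cc23)c1`, has not yet been tested. It differs from compound 3 in one place: hydroxy in place of chloro on an aromatic carbon. Among the measured compounds shown here, nothing among the measured compounds tells how such an exchange shifts the read-out. For the measured compounds named here, the step from compound 3 to compound 4 has no measured counterpart in this set, and all three known values are limits rather than numbers.

The most that can be said is that the measured series gives no sign of activity from which a change could be built. The step from compound 3 to compound 4 is expected to be a step that the limit leaves unreadable from compound 3 to compound 4, that is, no clear movement away from the limit. Compound 4 is accordingly expected to give about 60000 nM in this assay, within a range from 15000 nM to 200000 nM, with a substantial chance that only a limit is reported again.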

Compound 4, half-maximal inhibitory concentration: > 50000 nM
Compound 4: a limit, no number; the forecaster's own chance of this, stated with the estimate: 75%; the middle value does not contradict the limit.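

Compound 3 and compound 4 both end at a limit of the assay and not at a number, so the exchange of chloro for hydroxy between them cannot be read as a step. The compounds shown leave open which change to this series, if any, would give a measurable value: the limit of > 50000 nM in this assay, at which 4 of the 4 values shown sit.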